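Swapping cyclopropyl for tert-butoxy on the hydroxy side chain

The source may report more compounds than this note shows. Statements on the series, on what has been measured and on what is new or still open speak of the compounds shown alone.

Measured so far in an ADME assay on Caco-2 cells (Homo sapiens) for permeability, read by LC-MS, in the apical to basolateral direction, with a stated time of 60 min, at pH 6.5; a lower number here means that the compound crosses the layer more slowly, a higher number that the compound crosses the layer faster:
- compound 1 `O=C(NCc1cc(Cl)ccc1-n1cnnn1)[C@@H]1C[C@@H]2C[C@@H]2N1C(=O)[C@H](O)Cc1ccccn1` gives 1.2 10^-6 cm/s
- compound 2 `CC(C)(C)[C@@H](O)C(=O)N1CC(=O)C[C@H]1C(=O)NCc1cc(Cl)ccc1-n1cnnn1` gives 0.8 10^-6 cm/s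
- compound 3 `O=C(NCc1cc(Cl)ccc1-n1cnnn1)[C@@H]1C[C@@H]2C[C@@H]2N1C(=O)[C@H](O)CC1CC1` gives 3.6 10^-6 cm/s

Compound 3 gives the highest number of the three, with compound 1 nearest and compound 2 furthest; both gaps lie beyond the scatter. Compound 4 `CC(C)(C)OC[C@@H](O)C(=O)N1[C@H](C(=O)NCc2cc(Cl)ccc2-n2cnnn2)C[C@@H]2C[C@@H]21` has not yet been measured in this assay. It differs from compound 3 in one place: tert-butoxy in place of cyclopropyl on a saturated chain carbon, two bonds along the chain from a carbonyl carbon and an oxygen on a saturated carbon.

For the measured compounds named here, only one measured step touches the same position: a 3.0-fold higher number from compound 1 to compound 3 (0.48 log units; beyond the scatter), a modest rise when a cyclopropyl replaces a ring holding a nitrogen. The change to compound 4 goes the other way in kind, replacing the cyclopropyl with a group that brings in one hydrogen-bond acceptor, so a drop beyond the scatter is expected in this assay, though not necessarily as far as compound 1. Going by the values given here, compound 2, which carries a tert-butyl on a different core, gives 0.8 10^-6 cm/s, but no single-point step links it to compound 4.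

For compound 4 the expected step is a 1.8-fold lower number from compound 3 to compound 4 (0.26 log units; within the scatter). Compound 4 is estimated at 2 10^-6 cm/s, with a likely range from 0.9 10^-6 cm/s to 4 10^-6 cm/s.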

Compound 4, apparent permeability: 4.5 10^-6 cm/s
The estimate for compound 4 lay 2.3-fold (0.35 log units) below the measured number; measured number above the stated range.
By their numbers in this assay, from the lowest: compounds 2 and 1 (each within the scatter of the next); then compounds 3 and 4 (each within the scatter of the next).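

In this assay this position accepts tert-butoxy in place of cyclopropyl with no real change: a 1.3-fold higher number from compound 3 to compound 4 (0.10 log units; within the scatter) stays within the scatter, even though the entering group has no ring, has more heavy atoms and brings in one hydrogen-bond acceptor. The earlier rise on leaving pyridin-2-yl is therefore not tied to cyclopropyl, since a 3.8-fold higher number from compound 1 to compound 4 (0.57 log units; beyond the scatter) also lies beyond the scatter with a quite different group in its place. Nothing measured here tells what lies behind either step.

For the compounds shown here, only two groups at this position now share the upper level, so it remains open how far that level extends. An amine or a carboxylic acid at the same place could test this, as could a longer chain of carbon only.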